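Amide variation on a stilbene cinnamamide scaffold

This account rests on a few compounds, and the source may have more. Where it says the series, first, only, none or still open, it means among the compounds named here.

Three compounds share a core and differ only in the amine on the carbonyl carbon. Compound 1 `COc1ccc(/C=C/c2cc(OC)cc(OC)c2/C=C/C(=O)N2CCN(C)CC2)cc1` gives 2290 nM in a functional assay on MCF7 cells (Homo sapiens) for inhibition, read by MTT assay, with a stated time of 48 h; a higher number here means a weaker inhibitor, a lower number a stronger inhibitor. Compound 2 `COc1ccc(/C=C/c2cc(OC)cc(OC)c2/C=C/C(=O)N2CCCC2)cc1` gives 4200 nM in this assay, and compound 3 `CCCCN(CCCC)C(=O)/C=C/c1c(/C=C/c2ccc(OC)cc2)cc(OC)cc1OC` gives 3990 nM in this assay. Compound 2 stands at the upper end of the three numbers, yet its steps to both neighbours fall within the scatter: a 1.1-fold lower number from compound 2 to compound 3 (0.02 log units; within the scatter), and the reverse of a 1.8-fold higher number from compound 1 to compound 2 (0.26 log units; within the scatter). Likewise a 1.7-fold higher number from compound 1 to compound 3 (0.24 log units; within the scatter) is within the scatter, so across the three amines nothing beyond the scatter is seen.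

Compound 4 `CCCCCCNC(=O)/C=C/c1c(/C=C/c2ccc(OC)cc2)cc(OC)cc1OC` has not yet been measured. Relative to compound 2 the change is hexylamino in place of pyrrolidin-1-yl on a carbonyl carbon. The three measured steps all swap one amine for another on the same carbonyl carbon, and each stayed within the scatter, which bears directly on this step. Among the measured compounds shown here, the hexylamino group brings a hydrogen-bond donor that none of the measured amines has, a feature with no precedent among the three compounds, so it is a source of uncertainty rather than a basis for a direction.

Compound 4 is therefore expected to give about 4000 nM in this assay, within a range of 1800 nM to 9000 nM. The expected step is a 1.1-fold lower number from compound 2 to compound 4 (0.02 log units; within the scatter), no larger than the scatter.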

Compound 4, half-maximal inhibitory concentration: 5530 nM
For compound 4 the middle estimate is 1.4-fold (0.14 log units) below the measured one; measured number inside the range.
By their numbers in this assay, from the lowest: compounds 1, 3, 2 and 4 (each within the scatter of the next, the first and the last beyond it).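

In this assay the amine on the carbonyl carbon can now carry the amide hydrogen, and hexylamino still gives no step beyond the scatter against the two nearest amines, with a 1.3-fold higher number from compound 2 to compound 4 (0.12 log units; within the scatter) and a 1.4-fold higher number from compound 3 to compound 4 (0.14 log units; within the scatter) as the readings. Among the compounds shown here, the first step beyond the scatter in the set appears only against 4-methylpiperazin-1-yl, where a 2.4-fold higher number from compound 1 to compound 4 (0.38 log units; beyond the scatter) is a modest change, and compounds 2 and 3 remain within the scatter of both compound 1 and compound 4, so the four amines do not separate into clear groups. Nothing offered here accounts for that single step, and no measurement of any property of these amines accompanies the numbers.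

On these data alone, what remains open is whether the step belongs to the 4-methylpiperazin-1-yl group itself or only to the pairing of the two ends of a narrow spread, which a morpholin-4-yl or piperidin-1-yl amide on the same carbonyl carbon could test. As far as these compounds go, it is also open how far the position tolerates change, as a butylamino or octylamino chain, an unsubstituted amide or a carboxylic acid in place of the amide would show.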